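The compounds below may be only part of what the source reports. "The series", "measured", "known", "first", "only" and "open" are said of these compounds alone.

Measured compounds:
- compound 1, `O=C1OC(c2ccc(OCc3ccccc3)cc2)C(c2ccc(F)cc2)=C1O`: 0%
- compound 2, `O=C1OC(c2ccc(OCc3ccccc3)c(OCc3ccccc3)c2)C(c2ccc(F)cc2)=C1O`: 0%

In an assay on blood for inhibition of Polyunsaturated fatty acid 5-lipoxygenase (Homo sapiens), tested at 10 uM (a higher number here means a stronger effect of the compound at the concentration tested, a lower number a weaker effect), compound 1 gives 0%. Compound 2 carries one more benzyloxy group on an aromatic carbon of the shared core, and in this assay compound 2 gives 0%. Among the measured compounds shown here, the one measured step, no change at the digits printed from compound 1 to compound 2 (within the scatter), therefore shows no movement at all, and compound 1 stands level with compound 2, the only other compound measured here.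

Compound 3, `O=C1OC(c2ccc(O)cc2)C(c2ccc(F)cc2)=C1O`, has not yet been measured in this assay. It differs from compound 1 in a single place: hydrogen in place of benzyl on an oxygen on an aromatic ring. For the measured compounds named here, no measured step covers this particular change; the only step available, no change at the digits printed from compound 1 to compound 2 (within the scatter), concerns adding a benzyloxy group elsewhere and left the read-out flat. With both measured compounds showing no activity, the expectation for compound 3 is that a number 3 percentage points higher from compound 1 to compound 3 (within the scatter) will likewise be no change beyond the scatter. Compound 3 is accordingly estimated at 3%, within a range from 0% to 20%.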

Compound 3, a percentage reported as activity, at one concentration (the size of the read-out at that concentration, not a potency): 0%
Compound 3: the middle estimate sits 3 percentage points above what was measured; low and high end bracket the measured number.
By their numbers in this assay, from the lowest: compounds 1, 2 and 3 (each within the scatter of the next).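

Cutting the benzyloxy group back to hydroxy gives no change at the digits printed from compound 1 to compound 3 (within the scatter) in this assay. The earlier pair tested only the addition of a second benzyloxy group, whereas this step removes the benzyl from the oxygen on the aromatic ring, and the read-out stays flat in this direction too. With the read-out at the bottom of its scale in all three compounds, the step shows that neither the benzyl nor the free hydroxy on this oxygen produces a measurable effect at the concentration tested, and nothing available accounts for this result.

A flat result at the bottom of the scale cannot show whether this position matters at all, as there is no effect here for a change to reduce. On these data alone, whether a longer alkyl chain on this oxygen, or an amine or a carboxylic acid carried on the same aromatic ring, would give any effect in this assay remains open.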